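This account rests on a few compounds, and the source may have more. Where it says the series, first, only, none or still open, it means among the compounds named here.

In a functional assay on MCF7 cells (Homo sapiens) for inhibition, in the absence of a further agent (on this read-out higher numbers stand for weaker inhibition and lower numbers for stronger inhibition), compound 2 `Nc1ccc(-c2cc(=O)c3c(N)ccc(F)c3o2)cc1` gives 6.9 nM and sits level with compound 3 `Nc1ccc(-c2cc(=O)c3c(N)c(F)cc(F)c3o2)cc1` at 6 nM on these numbers, while compound 1 `Nc1ccc(-c2cc(=O)c3c(N)c(Cl)cc(Cl)c3o2)cc1` at 53 nM is clearly higher. Compound 4 `Nc1ccc(-c2cc(=O)c3c(N)ccc(Cl)c3o2)cc1` is still unmeasured and differs from compound 2 as follows: chloro in place of fluoro on an aromatic carbon. Among the measured compounds shown here, no measured step makes this swap. For the measured compounds named here, the only measured step, a 1.2-fold lower number from compound 2 to compound 3 (0.06 log units; within the scatter) (within the scatter), adds a fluoro and says little about it. A better guide comes from two values: compound 1 at 53 nM carries chloro in two places where compound 3 at 6 nM carries fluoro. For this single swap, a higher number, beyond the scatter but smaller than that gap, is therefore expected in this assay as the direction of change. By this estimate the expected size is a 2.9-fold higher number from compound 2 to compound 4 (0.46 log units; beyond the scatter) overall. For compound 4 the estimated value is 20 nM with 6 nM to 60 nM as the expected range.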

Compound 4, half-maximal inhibitory concentration: 9.8 nM
For compound 4 the middle estimate is 2.0-fold (0.31 log units) above the measured one, and the stated range covers the measured number.
By their numbers in this assay, from the lowest: compounds 3, 2 and 4 (each within the scatter of the next); then compound 1.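

In this assay, chloro can stand in place of fluoro at this position, para to an amino group, without a change beyond the scatter (a 1.4-fold higher number from compound 2 to compound 4 (0.15 log units; within the scatter)). The second chloro carries the larger step: with hydrogen in its place, the number falls clearly (a 5.4-fold lower number from compound 1 to compound 4 (0.73 log units; beyond the scatter)). Nothing available explains either result. Still open, from the compounds shown here alone, is whether a larger group at this position, such as bromo or methoxy, would also leave the number level, and whether hydrogen there would do the same.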